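From compound 3 to compound 4: a larger ring group

A few compounds are considered here, and "the series" means these few. Any claim that something is new, unique, unknown or untested is made for them only; others in the source may bear on it.

Compound 1 `Cc1ccc(NC(=S)OCCNC(=O)C(C)(C)Oc2ccc(Cl)cc2)cc1`: > 800000 nM
Compound 2 `O=C(NCCOC(=S)Nc1ccc([N+](=O)[O-])cc1Cl)c1cccnc1`: > 800000 nM
Compound 3 `CC(C)(Oc1ccc(Cl)cc1)C(=O)Oc1ccc(C(N)=S)cc1`: > 800000 nM

All three results come from an ADME assay on WI-38 cells (Homo sapiens) for cytotoxicity, read by MTT assay, with a stated time of 48 h; a higher number here means a weaker inhibitor, a lower number a stronger inhibitor. Each is a limit of the assay and not a number: the limit of > 800000 nM in this assay, at which 3 of the 3 values shown sit. Compound 3 stands at this limit, with > 800000 nM. The results therefore give no ranking of the three compounds.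

Compound 4 `CC(C)(Oc1ccc(Cl)cc1)C(=O)Oc1ccc(-c2cc(=S)ss2)cc1` has not yet been measured. It differs from compound 3 in one place, on an aromatic carbon of a six-membered aromatic ring of carbon only, para to a large group: a group of 6 heavy atoms (3 carbon, 3 sulfur; one five-membered aromatic ring with 2 hetero atoms) in place of a group of 3 heavy atoms (1 carbon, 1 nitrogen, 1 sulfur; no ring), on an aromatic carbon.

For the measured compounds named here, no measured step shows what a change of this kind does in this assay. The expectation therefore starts from a limit rather than a number. I expect compound 4 to stay near the limit or to move modestly toward a lower number, meaning a stronger inhibitor. The estimated step is an at least 1.6-fold lower number from compound 3 to compound 4 (0.20 log units; that floor lies within the scatter). For compound 4, the estimated value is 500000 nM, with an expected range from 100000 nM to 800000 nM.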

Compound 4, half-maximal inhibitory concentration: 764000 nM
Beside the measured number, compound 4's estimate is 1.5-fold (0.18 log units) below it, and the stated range covers the measured number.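

Compound 4 is the first compound shown whose result in this assay is a number and not a limit, at 764000 nM. On the aromatic carbon para to a large group, the group of 6 heavy atoms with its five-membered aromatic ring replaces the group of 3 heavy atoms without a ring, and the step is an at least 1.0-fold lower number from compound 3 to compound 4 (0.01 log units; that floor lies within the scatter). This step has only a floor, because compound 3 stands at a limit and not at a number: the limit of > 800000 nM in this assay, at which 3 of the 4 values shown sit.

The compounds shown leave open how an amine or a carboxylic acid at this place would read in this assay. They also leave open whether the value of compound 4 goes with the ring as such or with its sulfur atoms, a question that a thiophene ring at the same place would address.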